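Swapping an aryl ring for a tetrazole on a ketooxazole

This account rests on a few compounds, and the source may have more. Where it says the series, first, only, none or still open, it means among the compounds named here.

Compound 1: `O=C(CCCCCCc1ccccc1)c1ncc(-c2ccccc2C(=O)C(F)(F)F)o1` gives 5000 nM in an assay (Rattus norvegicus) for inhibition of Fatty-acid amide hydrolase 1 (Homo sapiens); a lower number here means a stronger inhibitor, a higher number a weaker inhibitor.
Compound 2: `COc1ccc(-c2cnc(C(=O)CCCCCCc3ccccc3)o2)cc1` gives 100 nM in this assay.

Of these two numbers, compound 2 stands lowest, and compound 1 sits far above it, well beyond the scatter. Compound 3, `O=C(CCCCCCc1ccccc1)c1ncc(-c2nnn[nH]2)o1`, has not yet been tested. It differs from compound 2 in one place: 1H-tetrazol-5-yl in place of 4-methoxyphenyl on an aromatic carbon. Among the compounds with values here, no measured pair shows this exact change, so the size of the step is open. The step from compound 2 to compound 3 is expected to be a 15-fold higher number from compound 2 to compound 3 (1.18 log units; beyond the scatter), toward a weaker inhibitor. Compound 3 is therefore estimated at 1500 nM, within 200 nM to 10000 nM.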

Compound 3, inhibition constant: 63 nM
For compound 3 the middle estimate is 24-fold (1.38 log units) above the measured one, and the stated range ends above it.
By their numbers in this assay, from the lowest: compounds 3 and 2 (each within the scatter of the next); then compound 1.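

On the aromatic carbon next to the ring oxygen, 1H-tetrazol-5-yl takes the place of 4-methoxyphenyl with a 1.6-fold lower number from compound 2 to compound 3 (0.20 log units; within the scatter) in this assay and thus without a change beyond the scatter. This position therefore accepts a five-membered aromatic ring with 4 hetero atoms as readily as a six-membered aromatic ring of carbon only. Nothing available explains why the two groups match. The compounds shown leave open whether a carboxylic acid or an amine on this carbon would give a similar number, and whether a methyl group on the tetrazole would change it.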